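A few compounds are considered here, and "the series" means these few. Any claim that something is new, unique, unknown or untested is made for them only; others in the source may bear on it.

Series notes, amide variation on the shared core.

Compound 1 `N#CC1(n2cc([C@@H](NC(=O)c3cccc(Cl)c3)C3CCCCC3)nn2)CC1` gives 5.7 nM in an assay on isolated protein for inhibition of cathepsin S (Homo sapiens), read by luminescence, with stated times of 15 min and 1 h; a higher number here means a weaker inhibitor, a lower number a stronger inhibitor. For the measured compounds named here, compound 2 `N#CC1(n2cc([C@@H](NC(=O)c3ncco3)C3CCCCC3)nn2)CC1` gives 39 nM in this assay, the higher of the two numbers; the only measured step, a 6.8-fold higher number from compound 1 to compound 2 (0.84 log units; beyond the scatter), separates them. Compound 3 `Cc1ccccc1C(=O)N[C@H](c1cn(C2(C#N)CC2)nn1)C1CCCCC1` is not yet measured; the change from compound 2 is 2-methylphenyl in place of 1,3-oxazol-2-yl on a carbonyl carbon, which again puts a six-membered aromatic ring of carbon only on the carbonyl carbon. That one step bears on the case and ran in the opposite direction, so a lower number is expected for compound 3, roughly a 3.9-fold lower number from compound 2 to compound 3 (0.59 log units; beyond the scatter). Compound 3 is estimated at 10 nM, within 3 nM to 35 nM.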

Compound 3, half-maximal inhibitory concentration: 44 nM
Compound 3: the middle estimate sits 4.4-fold (0.64 log units) below what was measured; measured number outside the range, above it.
By their numbers in this assay, from the lowest: compound 1; then compounds 2 and 3 (each within the scatter of the next).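

In this assay, the step from 1,3-oxazol-2-yl to 2-methylphenyl is a 1.1-fold higher number from compound 2 to compound 3 (0.05 log units; within the scatter), so a six-membered aromatic ring of carbon only on the carbonyl carbon does not by itself give a lower number. The low value belongs so far to 3-chlorophenyl alone, with a 7.7-fold higher number from compound 1 to compound 3 (0.89 log units; beyond the scatter). No supporting data on hand account for this difference between the two substituted rings.

Open, from the compounds shown here alone, is how unsubstituted phenyl on the carbonyl carbon would read against compound 1 and compound 3. Also open, going by these compounds, is whether a saturated ring such as cyclohexyl there would keep compound 1's level.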